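A few compounds are considered here, and "the series" means these few. Any claim that something is new, unique, unknown or untested is made for them only; others in the source may bear on it.

Measured so far:
- Compound 1, `Cc1cc(F)c(S(C)(=O)=O)cc1C(=O)N=C(N)N`: 44 nM
- Compound 2, `CCc1cc(C)c(C(=O)N=C(N)N)cc1S(C)(=O)=O`: 4.8 nM

For the measured compounds named here, in a functional assay for inhibition of sodium/hydrogen exchanger (Oryctolagus cuniculus) (a higher number here means a weaker inhibitor, a lower number a stronger inhibitor), compound 2 gives 4.8 nM, the lower of the two numbers recorded, with compound 1 as its only neighbour at 44 nM. Going by the values given here, the one step seen so far, a 9.2-fold lower number from compound 1 to compound 2 (0.96 log units; beyond the scatter), swapped a fluoro for an ethyl on the ring.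

Compound 3, `CCCc1cc(C)c(C(=O)N=C(N)N)cc1S(C)(=O)=O`, has not yet been tested in this assay. It differs from compound 2 by methyl in place of hydrogen on a saturated chain carbon, two bonds along the chain from an aromatic carbon, so the ethyl chain of compound 2 becomes a propyl chain. Among the compounds with values here, no measured pair shows this exact change. Within the data shown here, the only step that bears on it at all, a 9.2-fold lower number from compound 1 to compound 2 (0.96 log units; beyond the scatter), concerns a different exchange at the same ring carbon and shows that a small alkyl chain there is tolerated; it says nothing about lengthening that chain by one carbon. A step no larger than the scatter is therefore the most reasonable expectation, with no clear direction.

Compound 3 is expected to give about 4.5 nM in this assay, within a range of 1.5 nM to 14 nM. This estimate corresponds to a step of a 1.1-fold lower number from compound 2 to compound 3 (0.03 log units; within the scatter).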

Compound 3, half-maximal inhibitory concentration: 5.7 nM
Compound 3: the middle estimate sits 1.3-fold (0.10 log units) below what was measured; measured number inside the range.
By their numbers in this assay, from the lowest: compounds 2 and 3 (each within the scatter of the next); then compound 1.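

In this assay, extending the ethyl chain of compound 2 to the propyl chain of compound 3 gives a 1.2-fold higher number from compound 2 to compound 3 (0.07 log units; within the scatter), so at this position the added methyl leaves no difference that can be told from ordinary assay noise. The step from the fluoro compound also holds up with the longer chain, at a 7.7-fold lower number from compound 1 to compound 3 (0.89 log units; beyond the scatter), which means that two alkyl chains, not just one, now sit clearly on the stronger side of compound 1. No measurement here accounts for either observation.

The compounds shown leave open how far this tolerance for chain length runs: a butyl or longer chain might read the same as ethyl and propyl, or the numbers might start to climb at some length. They also leave open whether the shape and make-up of the group matter at this position, as would be tested by a branched isopropyl group, a cyclopropyl ring, or a chain ending in a hydroxyl group or an amine.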